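The source may hold more compounds than are shown below. What is called first, only, known or untested is meant among the compounds shown, and "the series" means these compounds.

In an ADME assay on a cell-free system (plasma, Rattus norvegicus) for protein binding, compound 2 `CNc1nccc(N2CC[C@H](NC(=O)Nc3ccc(OC)cc3)C2)n1` gives 86.3%. Compound 1 `CNc1nccc(N2CC[C@H](NC(=O)Nc3cccc(C#N)c3)C2)n1` gives 91.6%, within the scatter of compound 2, while compound 3 `CNc1nccc(N2CC[C@H](NC(=O)Nc3ccc(OC(F)(F)F)cc3)C2)n1` gives 98.1%, beyond the scatter from compound 2.

The next compound is compound 4 `CNc1nccc(N2CC[C@H](NC(=O)Nc3ccc(C)c(Cl)c3)C2)n1`, with this change: 3-chloro-4-methylphenyl in place of 4-methoxyphenyl on an amide-type nitrogen. In words, 3-chloro-4-methylphenyl stands in place of 4-methoxyphenyl on an amide-type nitrogen.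

Within the data shown here, two measured steps bear on this change. The first, a 1.6-fold higher unbound fraction from compound 1 to compound 2 (0.21 log units; within the scatter), is an exchange of the whole aromatic group on the same nitrogen, and it stays within the scatter. The second, a 7.2-fold lower unbound fraction from compound 2 to compound 3 (0.86 log units; beyond the scatter), shows that a change to the 4-methoxyphenyl group alone can move this assay clearly. Among the measured compounds shown here, it is also the only measured step that brings in halogen. Neither step tests chlorine or the 3-chloro-4-methylphenyl group directly, so a shift in the direction of compound 3, but smaller, is expected.

The expected step is a 3.0-fold lower unbound fraction from compound 2 to compound 4 (0.48 log units; beyond the scatter).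

Compound 4 is estimated at 95.5%, with an expected range of 91% to 98%.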

Compound 4, plasma protein binding: 98.9%
The estimate for compound 4 lay 4.1-fold (0.61 log units) (unbound fraction) above the measured number; the measured number lies above the stated range.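

In this assay, the exchange of 4-methoxyphenyl for 3-chloro-4-methylphenyl on the amide-type nitrogen gives a clear shift (a 12-fold lower unbound fraction from compound 2 to compound 4 (1.10 log units; beyond the scatter)), so replacing the whole aromatic group at this position can move the unbound fraction beyond the scatter, which the step between compound 1 and compound 2 did not show. The exchange of 3-cyanophenyl for the same group also goes beyond the scatter (a 7.6-fold lower unbound fraction from compound 1 to compound 4 (0.88 log units; beyond the scatter)), which sets compound 4 apart from both compound 1 and compound 2. No measurement at hand offers a reason for these steps.

Going by these compounds, the chlorine and the methyl enter together in compound 4, so their separate shares in the step remain open. Also open, on these data alone, is how the unbound fraction responds to an amine or a carboxylic acid on the aromatic ring.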